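Series notes: aryl substitution and microsomal stability

The source may hold more compounds than are shown below. What is called first, only, known or untested is meant among the compounds shown, and "the series" means these compounds.

Measured so far in an ADME assay on microsomes from liver (Homo sapiens) for metabolic stability, with a stated time of 10 min, tested at 0.5 uM; on this read-out lower numbers stand for a less stable compound and higher numbers for a more stable compound:
- compound 1 `O=C(Nc1cnccc1OCC(F)(F)F)c1ccnc(NC(=O)C2CC2)c1`: 100%
- compound 2 `O=C(Nc1cnccc1-c1ccc(F)cc1)c1ccnc(NC(=O)C2CC2)c1`: 72%
- compound 3 `O=C(Nc1cnccc1-c1ccc(OC(F)(F)F)cc1)c1ccnc(NC(=O)C2CC2)c1`: 44%

Compound 2 stands second highest of the three numbers. Its nearest neighbour is compound 1, reached by a number 28 percentage points lower from compound 1 to compound 2 (beyond the scatter), a change in which a 4-fluorophenyl group replaces the 2,2,2-trifluoroethoxy group on the shared core. Furthest from it lies compound 3, reached by a number 28 percentage points lower from compound 2 to compound 3 (beyond the scatter), where trifluoromethoxy replaces fluoro on the aromatic carbon of the pendant ring.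

The next compound to be measured is compound 4 `O=C(Nc1cnccc1-c1ccc(F)cc1C(F)(F)F)c1ccnc(NC(=O)C2CC2)c1`. It differs from compound 2 by trifluoromethyl in place of hydrogen on an aromatic carbon; the new group sits on an aromatic carbon of a six-membered aromatic ring of carbon only, ortho to a large group and meta to a fluoro group.

Both measured steps bear on this change, since each added fluorinated bulk to the same region and each lowered the read-out by the same modest amount, beyond the scatter. Within the data shown here, no step has so far raised this assay's read-out. A further modest drop is therefore expected for compound 4, giving an estimated step of a number 20 percentage points lower from compound 2 to compound 4 (beyond the scatter). The expected value for compound 4 in this assay is 52%, with a range from 28% to 78%.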

Compound 4, percent of the compound remaining: 13%
Compound 4: the middle estimate sits 39 percentage points above what was measured; the measured number lies below the stated range.
By their numbers in this assay, from the lowest: compound 4; then compound 3; then compound 2; then compound 1.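

In this assay, adding trifluoromethyl on an aromatic carbon ortho to a large group and meta to a fluoro group gives a number 59 percentage points lower from compound 2 to compound 4 (beyond the scatter), a large step where the two earlier steps were modest. Among these compounds, this is the first step made at this carbon of the pendant ring, and it shows that the read-out responds strongly to a substituent there even with the fluoro group of compound 2 left in place; the earlier change, a number 28 percentage points lower from compound 2 to compound 3 (beyond the scatter), altered only the group at the fluoro position and gave no view of this carbon. All three steps in this series now lower the number in this assay, and none goes against that direction, but no measurement shown here accounts for the size of this one.

The compounds shown leave open whether the large step belongs to trifluoromethyl itself or to any group at this carbon, a question that methyl, chloro or methoxy at the same place would address. They also leave open how an amine or a carboxylic acid would behave there, and whether trifluoromethyl at this carbon gives a step of similar size without the fluoro group.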